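The compounds below may be only part of what the source reports. "The series", "measured", "known", "first", "only" and "open" are said of these compounds alone.

Measured so far in a functional assay on MCF7 cells (Homo sapiens) for inhibition; a lower number here means a stronger inhibitor, a higher number a weaker inhibitor:
- compound 1 `CC/C(=C(/c1ccc(/C=C/C(=O)O)cc1)c1cc2ccccc2[nH]1)c1ccccc1C` gives 33 nM
- compound 2 `CC/C(=C(/c1ccc(/C=C/C(=O)O)cc1)c1cc2ccccc2[nH]1)c1ccccc1C(F)(F)F` gives 8 nM
- compound 3 `CC/C(=C(/c1ccc(/C=C/C(=O)O)cc1)c1cc2ccccc2[nH]1)c1ccc(C#N)cc1` gives 278 nM

Compound 3 carries the highest number of the three; compound 1 sits nearest to it and compound 2 furthest, both steps beyond the scatter. The next compound, compound 4 `CC/C(=C(/c1ccc(/C=C/C(=O)O)cc1)c1cc2ccccc2[nH]1)c1ccc(F)cc1Cl`, changes the aryl group on the double-bonded chain carbon: 2-chloro-4-fluorophenyl in place of 4-cyanophenyl on a double-bonded chain carbon bound to a double-bonded chain carbon and a saturated chain carbon.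

Within the data shown here, two measured steps bear on this change, since both end in the 4-cyanophenyl of compound 3: an 8.4-fold higher number from compound 1 to compound 3 (0.93 log units; beyond the scatter) and a 35-fold higher number from compound 2 to compound 3 (1.54 log units; beyond the scatter). Read backwards, leaving the 4-cyanophenyl for a 2-methylphenyl or a 2-(trifluoromethyl)phenyl lowered the number modestly to strongly. The 2-chloro-4-fluorophenyl of compound 4 stands closer to those two groups than to the 4-cyanophenyl, so a lower number in this assay is expected for compound 4, of a size between the two reverse steps, that is an 11-fold lower number from compound 3 to compound 4 (1.05 log units; beyond the scatter). For compound 4 the estimate is therefore 25 nM, within a range of 7 nM to 90 nM.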

Compound 4, half-maximal inhibitory concentration: 39 nM
The estimate for compound 4 lay 1.6-fold (0.19 log units) below the measured number; measured number inside the range.
By their numbers in this assay, from the lowest: compound 2; then compounds 1 and 4 (each within the scatter of the next); then compound 3.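

In this assay, moving from the 4-cyanophenyl to the 2-chloro-4-fluorophenyl group gives a 7.1-fold lower number from compound 3 to compound 4 (0.85 log units; beyond the scatter), so a halogen-bearing aryl group at this position also departs from the level of compound 3. That group does not reach the level of the 2-(trifluoromethyl)phenyl group, with a 4.9-fold higher number from compound 2 to compound 4 (0.69 log units; beyond the scatter), and compound 2 keeps the lowest number of the four. Compound 4 cannot be told apart from the 2-methylphenyl compound, with a 1.2-fold higher number from compound 1 to compound 4 (0.07 log units; within the scatter), so two differently substituted aryl groups read alike here.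

The separate contributions of the chlorine and the fluorine remain unresolved, and a 2-chlorophenyl, a 4-fluorophenyl or a 2-methoxyphenyl group on the same carbon would address that. Nothing available here explains why these aryl groups differ in this assay.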